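Acetamido to fluoro: step from compound 3 to compound 4

The source may hold more compounds than are shown below. What is called first, only, known or untested is meant among the compounds shown, and "the series" means these compounds.

Working notes on the series in a functional assay on cells for antagonist activity at Free fatty acid receptor 1 (Homo sapiens), read by TR-FRET and inositol phosphate accumulation, with a stated time of 2 h; on this read-out higher numbers stand for weaker inhibition and lower numbers for stronger inhibition. Compound 1 `Cc1cc(COc2ccccc2)nc(-c2ccccn2)n1` gives 794 nM. Compound 2 `Cc1cc(COc2ccc(Cl)cc2)nc(-c2ccccn2)n1` gives 251 nM. Compound 3 `CC(=O)Nc1cccc(OCc2cc(C)nc(-c3ccccn3)n2)c1` is reported only as a limit of the assay, > 39800 nM. Compound 3 therefore sits at the limit of > 39800 nM in this assay, at which 1 of the 3 values shown sits, the weak end of the three, with no number behind it.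

Compound 4 `Cc1cc(COc2cccc(F)c2)nc(-c2ccccn2)n1` has not yet been measured. It differs from compound 3 in one place: fluoro in place of acetamido on an aromatic carbon.

Within the data shown here, two measured steps bear on this change. The step of an at least 50-fold higher number from compound 1 to compound 3 (1.70 log units; beyond the scatter) shows that bringing in acetamido on that ring is costly, so taking it away should return most of that loss. The step of a 3.2-fold lower number from compound 1 to compound 2 (0.50 log units; beyond the scatter) shows that chloro in place of hydrogen on the same ring gave a modest gain; fluoro is a smaller halogen and a similar direction is plausible but not assured. Taken together, the step of an at least 79-fold lower number from compound 3 to compound 4 (1.90 log units; beyond the scatter) is expected to be large and toward stronger inhibition. Compound 3 carries a limit rather than a number, and the size of that step is bounded from one side only.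

Near the level of compound 1, compound 4 is estimated at 500 nM, with a range of 150 nM to 2000 nM.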

Compound 4, half-maximal inhibitory concentration: 794 nM
The estimate for compound 4 lay 1.6-fold (0.20 log units) below the measured number; the measured number falls inside the stated range.
By their numbers in this assay, from the lowest: compound 2; then compounds 1 and 4 (each within the scatter of the next). At a limit, above all of these: compound 3.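

Fluoro in place of hydrogen at this position, on an aromatic carbon meta to a large group, gives no change at the digits printed from compound 1 to compound 4 (within the scatter) in this assay, so the position accepts a small halogen without any measurable shift. Replacing acetamido with fluoro gives an at least 50-fold lower number from compound 3 to compound 4 (1.70 log units; beyond the scatter), which ties the loss in compound 3 to acetamido rather than to substitution on this ring as such, although the size of this step is bounded from one side only, since compound 3 is a limit of the assay: the limit of > 39800 nM in this assay, at which 1 of the 4 values shown sits. The change from 4-chlorophenyl to 3-fluorophenyl gives a 3.2-fold higher number from compound 2 to compound 4 (0.50 log units; beyond the scatter), so the gain seen with chloro in compound 2 does not appear in compound 4.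

The compounds shown do not separate the identity of the halogen from its place on the ring, which would take chloro at the position of the fluoro in compound 4, or fluoro at the position of the chloro in compound 2. They also leave open what in acetamido carries the loss, and a simple amine, a methoxy or a carboxylic acid at the same position would bear on that.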